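The compounds below may be only part of what the source reports. "The series", "measured", "known", "first", "only" and "open" are said of these compounds alone.

Compound 1 `C=C1C[C@]23C[C@@]1(O)CC[C@H]2c1ccc(O)c(C)c1[C@@H]3Cn1cc(-c2ccccn2)nn1`: in a functional assay on MCF7 cells (Homo sapiens) for cytotoxicity, read by MTT assay, with a stated time of 4 days (on this read-out lower numbers stand for stronger inhibition and higher numbers for weaker inhibition), compound 1 gives the limit > 20000 nM.
Compound 2 `C=C1C[C@]23C[C@@]1(O)CC[C@H]2c1ccc(O)c(C)c1[C@@H]3Cn1cc(-c2ccc(Br)cc2)nn1`: in this assay compound 2 gives the limit > 20000 nM.
Compound 3 `C=C1C[C@]23C[C@@]1(O)CC[C@@H]2c1cccc(C)c1[C@@H]3Cn1cc(-c2ccc(Br)cc2)nn1`: in this assay compound 3 gives the limit > 20000 nM.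

All three results are limits of the measurement, not numbers. Between compound 2 and compound 1 the change is pyridin-2-yl in place of 4-bromophenyl on an aromatic carbon, and the step is a step that the two limits leave unreadable from compound 2 to compound 1. The difference between the cores of compound 2 and compound 3 is not broken down here. Compound 4 `C=C1C[C@]23C[C@@]1(O)CC[C@@H]2c1cccc(C)c1[C@@H]3Cn1cc(-c2ccccn2)nn1` carries the same change against compound 3, namely (pyridin-2-yl in place of 4-bromophenyl on an aromatic carbon). For the measured compounds named here, because of the limit of > 20000 nM in this assay, at which 3 of the 3 values shown sit, the earlier step has no readable size, and the only guide is that every compound so far sits at the limit. For compound 4 the expected step is a step that the limit leaves unreadable from compound 3 to compound 4. Compound 4 is expected to give 30000 nM, most probably again as a limit rather than a number.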

Compound 4, half-maximal inhibitory concentration: > 20000 nM
Compound 4: only a limit was reported (the forecaster's own chance of this, stated with the estimate: 85%); the middle value is on the limit's open side.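

Compound 3 and compound 4 each give only a limit, not a number, and the step between them cannot be read. The compounds shown leave open whether pyridin-2-yl and 4-bromophenyl differ at all in this assay.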